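Tail flick series: side-chain change from compound 3 to compound 4

The source may report more compounds than this note shows. Statements on the series, on what has been measured and on what is new or still open speak of the compounds shown alone.

Measured so far:
- compound 1, `NC(=O)C[C@H](NC(=O)CN(c1ncnc2c1ncn2C1CCCCO1)C1CC1)C(=O)OCc1ccccc1`: 34.5%
- compound 2, `C[C@H](NC(=O)CN(c1ncnc2c1ncn2C1CCCCO1)C1CC1)C(=O)OCc1ccccc1`: 55.9%
- compound 3, `N=C(N)NCCC[C@H](NC(=O)CN(c1ncnc2c1ncn2C1CCCCO1)C1CC1)C(=O)OCc1ccccc1`: 34.3%

All three share one core and differ only in the group on the saturated chain carbon of the amino acid ester. In a functional assay on the whole organism (Tail, strain ICR) with Mus musculus as the target, in the tail flick test, with a stated time of 30 min, at a dose of 25 umol/kg by the oral route (on this read-out higher numbers stand for a stronger effect at the one dose given and lower numbers for a weaker effect), compound 3 gives 34.3%, the lowest of the three numbers; the step of a number 0.2 percentage points lower from compound 1 to compound 3 (within the scatter) is within the scatter, so those two cannot be ordered, while the step of a number 21.6 percentage points lower from compound 2 to compound 3 (beyond the scatter) lies beyond it.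

Compound 4, `CSCC[C@H](NC(=O)CN(c1ncnc2c1ncn2C1CCCCO1)C1CC1)C(=O)OCc1ccccc1`, has not yet been measured in this assay. The change is a group of 2 heavy atoms (1 carbon, 1 sulfur; no ring) in place of a group of 5 heavy atoms (2 carbon, 3 nitrogen; no ring), on a saturated chain carbon, three bonds along the chain from an amide-type nitrogen and a carbonyl carbon.

For the measured compounds named here, two measured steps bear on this. The step of a number 21.4 percentage points higher from compound 1 to compound 2 (beyond the scatter) and the step of a number 21.6 percentage points lower from compound 2 to compound 3 (beyond the scatter) both show that the compound with hydrogen at that carbon sits well above the two compounds carrying larger groups with hydrogen-bond donors. The entering methylsulfanyl group, like that hydrogen, carries no hydrogen-bond donors, so compound 4 is expected to land between compound 3 and compound 2 rather than beside compound 3. The expected step is a number 12.7 percentage points higher from compound 3 to compound 4 (beyond the scatter), a modest rise. Compound 4 is therefore estimated at 47%, with a range from 32% to 62%.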

Compound 4, a percentage reported as activity, at one dose (the size of the read-out at that dose, not a potency): 30%
The estimate for compound 4 lay 17 percentage points above the measured number, and the stated range ends above it.
By their numbers in this assay, from the lowest: compounds 4, 3 and 1 (each within the scatter of the next); then compound 2.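

In this assay, replacing the group on the chain with methylsulfanyl gives a number 4.3 percentage points lower from compound 3 to compound 4 (within the scatter), and the comparison with the carbamoyl compound gives a number 4.5 percentage points lower from compound 1 to compound 4 (within the scatter), so compounds 1, 3 and 4 cannot be ordered. The comparison with the compound carrying hydrogen on the saturated chain carbon gives a number 25.9 percentage points lower from compound 2 to compound 4 (beyond the scatter), which shows that a side chain with 0 hydrogen-bond donors can also sit well under compound 2, so donors at this position do not separate compound 2 from the rest. No supporting data bear on the reason for this grouping.

The compounds shown leave open whether any group in place of that hydrogen gives a number in this lower group, or only these three. A plain longer hydrocarbon chain, a carboxylic acid or an amine at this carbon would bear on that question.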